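Replacing the methylfuran with an oxime ether

The source may hold more compounds than are shown below. What is called first, only, known or untested is meant among the compounds shown, and "the series" means these compounds.

Measured compounds:
compound 1 `Cc1ncc(-c2ccccc2NCC2=NCCN2)o1`: < 5020 nM
compound 2 `Cc1ccc(-c2ccccc2NCC2=NCCN2)o1`: < 2000 nM

In a functional assay for activation of Alpha-1D adrenergic receptor (Homo sapiens) (on this read-out lower numbers stand for an effect already at smaller amounts and higher numbers for an effect only at larger amounts of compound), compound 1 gives < 5020 nM, which is a limit of the assay and not a number. Compound 2 gives < 2000 nM in this assay, again only a limit. The step that the two limits leave unreadable from compound 1 to compound 2 thus cannot be read, since compound 1 sits at the limit of < 5020 nM in this assay, at which 1 of the 2 values shown sits. Compound 2 sits at the limit of < 2000 nM in this assay, at which 1 of the 2 values shown sits. On the numbers shown, compound 2 stands only as a limit, with nothing more definite about where it lies.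

Compound 3 `CO/N=C/c1ccccc1NCC1=NCCN1` differs from compound 2 by a group of 4 heavy atoms (2 carbon, 1 nitrogen, 1 oxygen; no ring) in place of a group of 6 heavy atoms (5 carbon, 1 oxygen; one five-membered aromatic ring with 1 hetero atom), on an aromatic carbon. Within the data shown here, no measured step bears on this change, and the only step available is unreadable, so the expectation rests on the limit of compound 2 alone. Compound 3 is expected in this assay at 1500 nM, with a range of 150 nM to 15000 nM. This estimate corresponds to an expected step that the limit leaves unreadable from compound 2 to compound 3, whose direction cannot be checked against any measured step.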

Compound 3, half-maximal effective concentration: < 5020 nM
Compound 3: a limit, no number; the forecaster's own chance of this, stated with the estimate: 45%; the middle value is on the limit's open side.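

Among these compounds, compound 1, compound 2 and compound 3 all stand only as limits in this assay, not as numbers, and no step between them can be read. The compounds shown leave open how the group in compound 3 compares with 5-methylfuran-2-yl on this read-out.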